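Swapping the arylthio group for phenethylthio in a benzamide series

The source may report more compounds than this note shows. Statements on the series, on what has been measured and on what is new or still open speak of the compounds shown alone.

Measured compounds:
compound 1 `Nc1ccccc1NC(=O)/C=C/c1ccc(CSc2ccc(Cl)cc2)cc1` gives 1.94%
compound 2 `Cc1ccc(SCc2ccc(C(=O)Nc3ccccc3N)cc2)cc1` gives 33.8%
compound 3 `CC(C)(C)c1ccc(SCc2ccc(C(=O)Nc3ccccc3N)cc2)cc1` gives 9.73%

In a functional assay on HeLa cells (Homo sapiens) for inhibition, read by CCK-8 assay, with a stated time of 72 h, tested at 2 uM (a lower number here means less inhibition of growth, a higher number more inhibition of growth at the concentration tested), compound 2 stands highest of the three numbers. Its nearest neighbour is compound 3, reached by a number 24.1 percentage points lower from compound 2 to compound 3 (beyond the scatter), a change that put tert-butyl in place of methyl on an aromatic carbon. Going by the values given here, compound 1 differs from compound 2 in more than one place, so no single step connects them; its value simply lies furthest below that of compound 2.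

Compound 4 `Nc1ccccc1NC(=O)c1ccc(CSCCc2ccccc2)cc1` has not yet been measured in this assay. It differs from compound 2 by phenethyl in place of 4-methylphenyl on a sulfur. Among the compounds with values here, the only measured step that bears on this position is the one from compound 2 to compound 3, which altered the substituent on the same aromatic ring attached to the sulfur and lowered inhibition beyond the scatter. Within the data shown here, replacing the whole 4-methylphenyl group with phenethyl is a larger alteration at the same place, and no step in the set points to a gain.

Compound 4 is therefore expected to fall below compound 2, with an estimated step of a number 18.8 percentage points lower from compound 2 to compound 4 (beyond the scatter). The estimate for compound 4 is 15%, within a range from 3% to 32%.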

Compound 4, percent growth inhibition at one concentration: 27.7%
For compound 4 the middle estimate is 12.7 percentage points below the measured one, and the stated range covers the measured number.
By their numbers in this assay, from the lowest: compounds 1 and 3 (each within the scatter of the next); then compounds 4 and 2 (each within the scatter of the next).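

In this assay, the group on the sulfur could be replaced as a whole without a reading beyond the scatter: phenethyl in place of 4-methylphenyl gave a number 6.1 percentage points lower from compound 2 to compound 4 (within the scatter) for this pair. The earlier compounds shown here offered only the tert-butyl in place of methyl change on the aromatic ring, which gave a number 24.1 percentage points lower from compound 2 to compound 3 (beyond the scatter) in the same assay, so they showed only that this position could be sensitive. Compound 4 shows that this sensitivity does not apply to every replacement, since a group with one more carbon, and with its ring no longer attached directly to the sulfur, reads level with compound 2 within the scatter, and no measurement at hand explains why the two changes at this position read so differently.

The compounds shown leave open how far this holds for other groups on the sulfur, such as a chain longer than phenethyl, a benzyl group, or a phenethyl group carrying an amine on its ring. Compound 1, at 1.94%, differs from compound 2 in more than one place, so what separates those two compounds also stays unresolved.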